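Styryl in place of aryl on the core of compound 2

This account rests on a few compounds, and the source may have more. Where it says the series, first, only, none or still open, it means among the compounds named here.

Compound 1 `COc1ccc(-c2cc3cc(-c4ccccc4)cc(C(C)=O)c3[nH]2)cc1` gives 64.5% in a functional assay on MCF7 cells (Homo sapiens) for cytotoxicity, read by MTT assay, with a stated time of 2 days, tested at 10 uM; on this read-out higher numbers stand for a weaker effect at the one concentration tested and lower numbers for a stronger effect. Among the measured compounds shown here, compound 2 `COc1ccc(-c2cc(C(C)=O)c3[nH]c(-c4ccc(OC)cc4)cc3c2)cc1` gives 56.4% in this assay, and the single measured step, a number 8.1 percentage points lower from compound 1 to compound 2 (within the scatter), lies within the scatter, so compound 2 stands level with compound 1. Compound 3 `COc1ccc(-c2cc3cc(/C=C/c4ccc(F)cc4)cc(C(C)=O)c3[nH]2)cc1` carries 2-(4-fluorophenyl)ethenyl in place of 4-methoxyphenyl on an aromatic carbon. For the measured compounds named here, no measured step exchanges a whole ring-bearing group at this place; the one step known, methoxy in place of hydrogen, moved nothing beyond the scatter. Compound 3 is therefore expected at 57%, with a range of 30% to 85%. The expected step is a number 0.6 percentage points higher from compound 2 to compound 3 (within the scatter), not beyond the scatter.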

Compound 3, a percentage reported as activity, at one concentration (the size of the read-out at that concentration, not a potency): 76.5%
Beside the measured number, compound 3's estimate is 19.5 percentage points below it; the range from low to high includes it.
By their numbers in this assay, from the lowest: compounds 2 and 1 (each within the scatter of the next); then compound 3.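

Both steps, a number 20.1 percentage points higher from compound 2 to compound 3 (beyond the scatter) and a number 12 percentage points higher from compound 1 to compound 3 (beyond the scatter), point to a weaker effect with 2-(4-fluorophenyl)ethenyl on this aromatic carbon. Among the compounds shown here, this is the first change to pass the scatter, so this place responds to a swap of the whole ring-bearing group, as the added methoxy did not show. Nothing at hand explains the shift. As far as these compounds go, it remains open whether the ethenyl link or the fluorine carries the step, and how an amine or a carboxylic acid at this place would read.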